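A Chlorophenyl Exchange from Compound 3 to Compound 4

The source may hold more compounds than are shown below. What is called first, only, known or untested is meant among the compounds shown, and "the series" means these compounds.

Of the compounds shown here, three sharing one core have been measured in a physicochemical assay for solubility, in phosphate buffer, at pH 7.4; a higher number here means a more soluble compound, a lower number a less soluble compound. Compound 1 `CCOC(=O)c1c(-c2ccccc2Cl)[nH]c2cc(OC)ccc2c1=O` gives 28000 nM. Compound 3 `CCOC(=O)c1c(-c2cccc(Cl)c2)[nH]c2cc(OC)ccc2c1=O` gives 58000 nM, the higher of the two actual numbers and the closest to compound 1. Compound 2 `CCOC(=O)c1c(-c2cccc(OC)c2)[nH]c2cc(OC)ccc2c1=O` gives > 100000 nM, which is a limit of the assay and not a number.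

Compound 4 `CCOC(=O)c1c(-c2ccc(Cl)cc2)[nH]c2cc(OC)ccc2c1=O` has not yet been measured. It carries 4-chlorophenyl in place of 3-chlorophenyl on an aromatic carbon, next to the ring nitrogen (4-chlorophenyl in place of 3-chlorophenyl on an aromatic carbon).

Within the data shown here, the nearest precedent is the exchange of 2-chlorophenyl for 3-chlorophenyl, a 2.1-fold higher number from compound 1 to compound 3 (0.32 log units; beyond the scatter), a modest step just beyond the scatter. The two steps involving methoxy are less direct. One runs an at least 3.5-fold higher number from compound 1 to compound 2 (0.55 log units; beyond the scatter), and the other runs an at least 1.7-fold lower number from compound 2 to compound 3 (0.23 log units; that floor lies within the scatter), with its floor within the scatter. Among the measured compounds shown here, no measured compound yet carries 4-chlorophenyl, so the data do not fix a direction. A small step at most is expected, and it should not pass beyond the scatter. The expected change is a 1.3-fold lower number from compound 3 to compound 4 (0.11 log units; within the scatter). Compound 4 is estimated at 45000 nM, with an expected range of 18000 nM to 95000 nM.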

Compound 4, solubility: 3000 nM
Beside the measured number, compound 4's estimate is 15-fold (1.18 log units) above it, and the stated range ends above it.
By their numbers in this assay, from the lowest: compound 4; then compound 1; then compound 3. At a limit, above all of these: compound 2.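

In this assay, among these compounds, the exchange of 3-chlorophenyl for 4-chlorophenyl, which keeps the same atoms joined differently, gives a 19-fold lower number from compound 3 to compound 4 (1.29 log units; beyond the scatter) and is a large step, while the only earlier exchange between chlorophenyl groups, a 2.1-fold higher number from compound 1 to compound 3 (0.32 log units; beyond the scatter), was modest. The 2-chlorophenyl group also stands well above the new group, with a 9.3-fold lower number from compound 1 to compound 4 (0.97 log units; beyond the scatter) as the step, so the three chlorophenyl compounds do not run in one steady direction: compound 3 has the highest number and compound 4 the lowest. The step from the methoxy compound, an at least 33-fold lower number from compound 2 to compound 4 (1.52 log units; beyond the scatter), is large but gives only a floor, since compound 2 stands at a limit and not a number: the limit of > 100000 nM in this assay, at which 1 of the 4 values shown sits.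

The compounds shown leave open whether 4-methoxyphenyl would fall as far as 4-chlorophenyl, and so whether the drop goes with the chlorine or with any group placed there. They also leave open what an amine or a carboxylic acid at that place on the phenyl ring would do, and they give no cause for the drop.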